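Nitro in place of fluoro on a shared core

The source may hold more compounds than are shown below. What is called first, only, known or untested is meant among the compounds shown, and "the series" means these compounds.

In a functional assay on HeLa cells (Homo sapiens) for inhibition, read by MTT assay, with a stated time of 72 h (on this read-out lower numbers stand for stronger inhibition and higher numbers for weaker inhibition), compound 1 (`COc1cc(OC)c(OC)cc1/C=C/C(=O)c1ccc(Cl)cc1`) gives 36500 nM and compound 2 (`COc1ccc(C(=O)/C=C/c2cc(OC)c(OC)cc2OC)cc1`) gives 37600 nM. Compound 3 (`COc1cc(OC)c(OC)cc1/C=C/C(=O)c1ccc(F)cc1`) gives 28600 nM, within the scatter of both. Compound 4 (`COc1cc(OC)c(OC)cc1/C=C/C(=O)c1ccc([N+](=O)[O-])cc1`) carries nitro in place of fluoro on an aromatic carbon. Three measured swaps at this same place bear on it: a 1.0-fold higher number from compound 1 to compound 2 (0.01 log units; within the scatter), a 1.3-fold lower number from compound 1 to compound 3 (0.11 log units; within the scatter) and a 1.3-fold lower number from compound 2 to compound 3 (0.12 log units; within the scatter). All three stay within the scatter, but none of them involves nitro, so the data cannot rule out a larger step. No step beyond the scatter is expected, in either direction. The expected change is a 1.0-fold lower number from compound 3 to compound 4 (0.01 log units; within the scatter). For compound 4 the estimated value is 28000 nM, with an expected range of 10000 nM to 60000 nM.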

Compound 4, half-maximal inhibitory concentration: > 150000 nM
Compound 4 gave a limit, no number (the forecaster's own chance of this, stated with the estimate: 5%); middle value at least 5.3-fold (0.72 log units) away from the limit.
By their numbers in this assay, from the lowest: compounds 3, 1 and 2 (each within the scatter of the next). At a limit, above all of these: compound 4.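

In this assay compound 4 gives a limit, not a number: the limit of > 150000 nM in this assay, at which 1 of the 4 values shown sits. Chloro, methoxy and fluoro at this place all sat within the scatter of one another, so the position looked indifferent to the swap, but nitro moves the read-out beyond the scatter: an at least 5.2-fold higher number from compound 3 to compound 4 (0.71 log units; beyond the scatter), an at least 3.9-fold higher number from compound 2 to compound 4 (0.60 log units; beyond the scatter) and an at least 4.1-fold higher number from compound 1 to compound 4 (0.61 log units; beyond the scatter). This place therefore does respond to what sits on it, with weaker inhibition under nitro.

The compounds shown leave open whether this loss is peculiar to nitro or would also come with a nitrile or a carboxylic acid at this place. They also leave open why nitro parts from the other three groups, and how far past its limit compound 4 lies.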